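The compounds below may be only part of what the source reports. "The series", "measured", "known", "first", "only" and "open" are said of these compounds alone.

Measured in a functional assay on MDA-MB-231 cells (Homo sapiens) for antiproliferative activity, read by MTT assay; a lower number here means a stronger inhibitor, a higher number a weaker inhibitor:
- Compound 1 `CC/C=C\C/C=C\C/C=C\CCCCCCCc1cc(=O)c2c(O)cc(OCOC)c(C)c2o1`: 6790 nM
- Compound 2 `CCCCCCCCCCCCCCCc1cc(=O)c2c(O)c(C)c(OCOC)cc2o1`: > 87000 nM, a limit of the assay and not a number
- Compound 3 `CCCCC/C=C\C/C=C\CCCCCCCc1cc(=O)c2c(O)cc(O)c(C)c2o1`: 6790 nM

Compound 1 stands level with compound 3, the two values lying within the usual scatter. The next compound to be tested is compound 4 `CC/C=C\C/C=C\C/C=C\CCCCCCCc1cc(=O)c2c(O)c(C)c(OCOC)c(C)c2o1`, in which methyl takes the place of hydrogen on an aromatic carbon of the core of compound 1, ortho to a hydroxy group and ortho to a methoxymethoxy group (methyl in place of hydrogen on an aromatic carbon). Among the compounds with values here, no measured pair isolates this change. The expectation therefore starts from compound 1 at 6790 nM. A small step towards weaker inhibition in this assay is expected, the estimate being a 1.3-fold higher number from compound 1 to compound 4 (0.12 log units; within the scatter). The estimated value for compound 4 is 9000 nM, with an expected range from 3000 nM to 35000 nM.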

Compound 4, half-maximal inhibitory concentration: 16100 nM
Estimate against measurement, compound 4: 1.8-fold (0.25 log units) below; low and high end bracket the measured number.
By their numbers in this assay, from the lowest: compounds 1 and 3 (each within the scatter of the next); then compound 4. At a limit, above all of these: compound 2.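

Methyl in place of hydrogen on this aromatic carbon, ortho to a hydroxy group and ortho to a methoxymethoxy group, now has a measured pair: in this assay it gives a 2.4-fold higher number from compound 1 to compound 4 (0.37 log units; beyond the scatter), so inhibition is modestly weaker with the added methyl. The earlier compounds shown here gave no reading of this change at any position. Nothing measured here accounts for the step. On these data alone, whether an amine or a fluorine atom on the same carbon would shift the number in the same direction stays open, as does whether the methyl step holds with another chain on the core.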